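This account rests on a few compounds, and the source may have more. Where it says the series, first, only, none or still open, it means among the compounds named here.

Working notes on the chalcone-type series.

Compound 1 `O=C(/C=C/c1cccc(C(F)(F)F)c1)c1cccc(O)c1` is the reference point for the present step. In a functional assay on RAW264.7 cells (Mus musculus) for inhibition, read by fluorescence, with stated times of 1 h, 24 h and 30 min (on this read-out lower numbers stand for stronger inhibition and higher numbers for weaker inhibition), compound 1 has no result: its entry reads "not determined" (no result reported), so no single number anchors it. Going by the values given here, the only measured neighbour is compound 2 `O=C(/C=C/c1cccc(C(F)(F)F)c1)c1ccc(O)cc1`, which carries the same trifluoromethyl-bearing ring as compound 1 and differs only in the placement of the phenol hydroxyl on the other ring. In this assay compound 2 gives 1440 nM, which is the sole figure in hand for the series. Among the compounds with values here, no pair of measured compounds differing in one place exists, so no step size is known.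

Compound 3 `O=C(/C=C/c1cccc(OC(F)(F)F)c1)c1cccc(O)c1` is the next member. It differs from compound 1 as follows: trifluoromethoxy in place of trifluoromethyl on an aromatic carbon. Within the data shown here, with nothing measured for compound 1 and no step of this kind recorded anywhere in the set, the working assumption for this assay is a change of no particular direction and none beyond the usual scatter. On that basis compound 3 is expected to give 1500 nM in this assay, with a plausible range from 400 nM to 6000 nM, taking compound 2 at 1440 nM as the nearest guide.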

Compound 3, half-maximal inhibitory concentration: > 10000 nM
Compound 3 ended at the assay's limit; the forecaster's own chance of this, stated with the estimate: 15%; at least 6.6-fold (0.82 log units) between middle value and limit.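

In this assay compound 3 gives > 10000 nM, which is a limit of the assay and not a number. Going by these compounds alone, compound 1 has no single number here, so no step between compound 1 and compound 3 can be read. Still open, on these data alone, is whether trifluoromethoxy in place of trifluoromethyl on an aromatic carbon changes inhibition at all.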